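Cytotoxicity of ester side chains on a shared quinolinone core

A few compounds are considered here, and "the series" means these few. Any claim that something is new, unique, unknown or untested is made for them only; others in the source may bear on it.

Measured compounds:
compound 1 `CCCC(=O)OCCc1c(-c2ccccc2Cl)c2cc(Cl)ccc2[nH]c1=O`: 52000 nM
compound 2 `CCCCC(=O)OCCc1c(-c2ccccc2Cl)c2cc(Cl)ccc2[nH]c1=O`: 200000 nM
compound 3 `N#CCC(=O)OCCc1c(-c2ccccc2Cl)c2cc(Cl)ccc2[nH]c1=O`: 100000 nM

In an ADME assay on HepG2 2.2.15 cells (Homo sapiens) for cytotoxicity (on this read-out higher numbers stand for lower toxicity in this test and lower numbers for higher toxicity in this test), compound 3 gives 100000 nM, the second highest of the three numbers. Its nearest neighbour is compound 1, with a 1.9-fold higher number from compound 1 to compound 3 (0.28 log units; within the scatter), and its furthest is compound 2, with a 2.0-fold lower number from compound 2 to compound 3 (0.30 log units; within the scatter); both gaps lie within the scatter, so on these numbers compound 3 is not distinguished from either.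

Compound 4 `O=C(OCCc1c(-c2ccccc2Cl)c2cc(Cl)ccc2[nH]c1=O)C1CCCC1` has not yet been measured. It differs from compound 3 in a single place: cyclopentyl in place of cyanomethyl on a carbonyl carbon. Going by the values given here, the steps that bear on this change are the two in which a cyano group replaced a small alkyl chain on a saturated chain carbon bound to a carbonyl carbon, a 1.9-fold higher number from compound 1 to compound 3 (0.28 log units; within the scatter) and a 2.0-fold lower number from compound 2 to compound 3 (0.30 log units; within the scatter), neither beyond the scatter. Among the compounds with values here, the only step beyond the scatter, a 3.8-fold higher number from compound 1 to compound 2 (0.59 log units; beyond the scatter), came from lengthening the chain by one carbon. Exchanging cyanomethyl for cyclopentyl returns the ester to an all-carbon group, larger than either of those chains, and compound 4 is therefore expected to sit in the upper part of the measured range: the estimated step is a 1.5-fold higher number from compound 3 to compound 4 (0.18 log units; within the scatter), giving an estimate for compound 4 of 150000 nM, within 60000 nM to 400000 nM.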

Compound 4, half-maximal cytotoxic concentration: 46000 nM
The estimate for compound 4 lay 3.3-fold (0.51 log units) above the measured number; the whole stated range lies above it.
By their numbers in this assay, from the lowest: compounds 4, 1, 3 and 2 (each within the scatter of the next, the first and the last beyond it).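

In this assay the carbonyl carbon now shows a step beyond the scatter that does not come from lengthening an open chain: putting cyclopentyl in place of cyanomethyl gives a 2.2-fold lower number from compound 3 to compound 4 (0.34 log units; beyond the scatter), whereas the earlier exchanges between a small alkyl chain and a cyano-bearing chain stayed within the scatter. The ring also parts from the open butyl chain, with a 4.3-fold lower number from compound 2 to compound 4 (0.64 log units; beyond the scatter), yet it cannot be told apart from the propyl chain, with a 1.1-fold lower number from compound 1 to compound 4 (0.05 log units; within the scatter), so among these four esters a larger all-carbon group does not go with a higher number. Nothing available here accounts for these gaps.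

The compounds shown leave open whether the gap between cyclopentyl and butyl belongs to the ring itself or to branching at the carbon bound to the carbonyl, which cyclobutyl, cyclohexyl or an isopropyl group at this place could separate. They also leave open whether the number keeps rising along chains longer than butyl, since a single step carries that trend, and where an amine or a carboxylic acid on the chain would fall.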